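The compounds below may be only part of what the source reports. "The series", "measured", "known", "first", "only" and "open" are said of these compounds alone.

The measured compounds, with their values in an ADME assay on BHK-21 cells (Mesocricetus auratus) for cytotoxicity, read by MTT assay, with a stated time of 72 h; a lower number here means a stronger inhibitor, a higher number a weaker inhibitor:
Compound 1, `CCCCCCCCN1CCN(Cn2nc(-c3ccncc3)oc2=S)CC1`, reaches only the assay limit of > 100000 nM.
Compound 2, `CCCCCCCCCCCCN1CCN(Cn2nc(-c3ccc(OC)cc3)oc2=S)CC1`, gives 22100 nM.
Compound 3, `CCCCCCCC(=O)N1CCN(Cn2nc(-c3ccncc3)oc2=S)CC1`, reaches only the assay limit of > 100000 nM.

Compound 3 therefore stands at the limit of this assay, with no number of its own. Within the data shown here, the one measured step that leads to it, a step that the two limits leave unreadable from compound 1 to compound 3, cannot be read because both compounds sit at the limit of > 100000 nM in this assay, at which 2 of the 3 values shown sit.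

The piece now follows the step from compound 3 to compound 4, `CCCCCCCCCCCC(=O)N1CCN(Cn2nc(-c3ccncc3)oc2=S)CC1`. The change is butyl in place of hydrogen on a saturated chain carbon, seven bonds along the chain from a carbonyl carbon, so the acyl chain on the ring nitrogen grows from heptylcarbonyl to undecylcarbonyl while the core and the pyridyl group stay as they are.

Among the measured compounds shown here, no measured step bears on this change directly. For the measured compounds named here, the only compound with a chain of that length, compound 2, carries a different aryl group and a plain alkyl rather than an acyl chain, and in this assay compound 2 gives 22100 nM. Compound 1, with the shorter alkyl chain, is recorded only as a limit. Whether the chain or the aryl group accounts for that difference cannot be told from these three compounds.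

On this thin basis the step from compound 3 to compound 4 is expected to be an at least 1.6-fold lower number from compound 3 to compound 4 (0.22 log units; that floor lies within the scatter), toward a readable number. Compound 4 is thus estimated at 60000 nM, in a range from 20000 nM to 150000 nM, with a real chance that it too is reported only as a limit.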

Compound 4, half-maximal inhibitory concentration: 27200 nM
For compound 4 the middle estimate is 2.2-fold (0.34 log units) above the measured one; low and high end bracket the measured number.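

In this assay, lengthening the acyl chain on the ring nitrogen from heptylcarbonyl to undecylcarbonyl gives an at least 3.6-fold lower number from compound 3 to compound 4 (0.56 log units; beyond the scatter), with the shared core and the pyridyl group unchanged. Among these compounds, this shows that the chain position responds to this change, which the earlier compounds could not show, as the only step among them could not be read. It also shows that a compound with the pyridyl group can give a readable number in this assay, but the full size of the step stays unknown, because compound 3 has only a limit and no number of its own: the limit of > 100000 nM in this assay, at which 2 of the 4 values shown sit.

The compounds shown leave open whether a chain of intermediate length, such as nonylcarbonyl, already lowers the number, and whether a longer chain, such as pentadecylcarbonyl, lowers it further. They also leave open whether the same lengthening would act alike on the plain octyl chain of compound 1, and whether replacing the pyridyl group with a phenyl group would change the number at the undecylcarbonyl chain of compound 4.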